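This account rests on a few compounds, and the source may have more. Where it says the series, first, only, none or still open, it means among the compounds named here.

Measured in a functional assay on NALM-6 cells (Homo sapiens) for cytotoxicity, with a stated time of 72 h; a lower number here means that less compound is needed, a higher number that more compound is needed for the effect:
- compound 1 `COc1ccc(/C=C/[C@@](C)(/C=C/c2ccc(O)cc2)CCC=C(C)C)cc1`: > 43400 nM, a limit
- compound 2 `CC(C)=CCC[C@@](C)(/C=C/c1ccc(C)cc1)/C=C/c1ccc(O)cc1`: > 43400 nM, a limit

Compound 2 gives no number, and it stands at the limit of > 43400 nM in this assay, at which 2 of the 2 values shown sit. Among the compounds with values here, the only measured step is a step that the two limits leave unreadable from compound 1 to compound 2, so it offers no size to carry forward and no direction.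

Compound 3 `CC(C)=CCC[C@](C)(/C=C/c1ccc(O)cc1)/C=C/c1cccc(Cl)c1` is the next analogue, with one structural difference: 3-chlorophenyl in place of 4-methylphenyl on a double-bonded chain carbon bound to a double-bonded chain carbon. Nothing measured in the series covers this replacement. Compound 2 remains at > 43400 nM, which is a limit, so the expectation in this assay is no clear shift, and compound 3 will probably also return only a limit. The expected size of the change is a step that the limit leaves unreadable from compound 2 to compound 3, though this is weakly grounded. Compound 3 is estimated at 45000 nM, with an expected range of 15000 nM to 100000 nM.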

Compound 3, half-maximal effective concentration: > 43400 nM
Compound 3 gave a limit, no number (the forecaster's own chance of this, stated with the estimate: 70%); the middle value is on the limit's open side.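

In this assay compound 3 gives > 43400 nM, a limit. The steps to compound 3 from compound 1 and compound 2 therefore cannot be read. The compounds shown leave open whether any replacement on the shared core gives a measurable value in this assay.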